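The source may hold more compounds than are shown below. What is called first, only, known or untested is meant among the compounds shown, and "the series" means these compounds.

In an ADME assay on a cell-free system (plasma, Homo sapiens) for protein binding, read by LC-MS, with a stated time of 4 h, tested at 1 ug/mL, compound 3 `CN1CCNC(=O)COc2ccc(Cl)cc2C(=O)N2CCCC[C@H]2c2cc3nc([C@H]4C[C@H](O)C4)cc1n3n2` gives 90.7%. Compound 1 `CN1CCNC(=O)COc2ccc(F)cc2C(=O)N2CCCC[C@H]2c2cc3nc(N4CCC4)cc1n3n2` gives 87%, and compound 2 `Cc1ccc2c(c1)C(=O)N1CCCCC1c1cc3nc(N4CCC4)cc(n3n1)N(C)CCNC(=O)CO2` gives 93.6%. Compound 3 lies within the scatter of both, so the numbers cannot tell it apart from either one.

Compound 4 `Cc1ccc2c(c1)C(=O)N1CCCC[C@H]1c1cc3nc([C@H]4C[C@H](O)C4)cc(n3n1)N(C)CCNC(=O)CO2` has not yet been measured. It differs from compound 3 in one place, with methyl in place of chloro on an aromatic carbon. For the measured compounds named here, no two measured compounds differ in only one place, so this swap has no direct precedent here. Compound 2 also carries the methyl and gives 93.6%, but it differs from compound 3 in other places too, and its value remains within the scatter of compound 3.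

A change beyond the scatter in this assay is therefore not expected, and no direction is favoured with any confidence. The expected change is small, a 1.1-fold higher unbound fraction from compound 3 to compound 4 (0.03 log units; within the scatter). Compound 4 is estimated at 90%, with an expected range from 83% to 95%.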

Compound 4, plasma protein binding: 88.8%
For compound 4 the middle estimate is 1.1-fold (0.05 log units) (unbound fraction) below the measured one; measured number inside the range.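

In this assay, for the compounds shown here, this pair gives the first direct reading of methyl in place of chloro on this aromatic carbon, with the rest of the molecule held constant: a 1.2-fold higher unbound fraction from compound 3 to compound 4 (0.08 log units; within the scatter). The earlier compounds shown here differed in more than one place, so they could not isolate this swap. For this single pair, the measurement does not separate chloro from methyl at this position, and nothing measured here offers an explanation for the size of the step.

One pair cannot show whether the same swap would read the same way on a different core. The compounds shown also leave open how plasma protein binding would respond to a very different group on this aromatic carbon, such as a carboxylic acid, an amine or a longer alkyl chain.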